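The source may hold more compounds than are shown below. What is called first, only, known or untested is meant among the compounds shown, and "the series" means these compounds.

Measured so far in an assay on isolated protein for binding affinity to Equilibrative nucleoside transporter 1 (Homo sapiens); a higher number here means a weaker inhibitor, a lower number a stronger inhibitor:
compound 1, `CC(C)Sc1nc(N)nc2c1ncn2[C@@H]1O[C@H](CO)[C@@H](O)[C@H]1O`: 191000 nM
compound 2, `CSc1nc(N)nc2c1ncn2[C@@H]1O[C@H](CO)[C@@H](O)[C@H]1O`: 204000 nM
compound 3, `Nc1nc(SCc2ccccc2[N+](=O)[O-])c2ncn([C@@H]3O[C@H](CO)[C@@H](O)[C@H]3O)c2n1`: 4570 nM

Compound 3 stands lowest of the three numbers in this assay. Its nearest neighbour is compound 1, with a 42-fold lower number from compound 1 to compound 3 (1.62 log units; beyond the scatter); the furthest is compound 2, with a 45-fold lower number from compound 2 to compound 3 (1.65 log units; beyond the scatter). Between compound 1 and compound 2 the difference is a 1.1-fold higher number from compound 1 to compound 2 (0.03 log units; within the scatter), so the two small alkyl substituents on the sulfur give the same picture.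

Compound 4, `CC(=O)c1cc(Cl)ccc1Sc1nc(N)nc2c1ncn2[C@@H]1O[C@H](CO)[C@@H](O)[C@H]1O`, is not yet measured. It differs from compound 3 in one place: 2-acetyl-4-chlorophenyl in place of 2-nitrobenzyl on a sulfur.

Both large steps in the series, from compound 1 and from compound 2 to compound 3, were gained by putting an aromatic ring onto the sulfur substituent, and compound 4 keeps an aromatic ring there. Within the data shown here, no measured pair separates a ring bound directly to the sulfur from one bound through a saturated carbon, and none separates the two substitution patterns on the ring, so the numbers give no direction for the step itself. The expectation is therefore that compound 4 remains near compound 3, with the estimated step of a 1.3-fold higher number from compound 3 to compound 4 (0.12 log units; within the scatter) within or close to the scatter. For compound 4 in this assay the estimate is 6000 nM, expected to fall between 1500 nM and 25000 nM.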

Compound 4, half-maximal inhibitory concentration: 14500 nM
Compound 4: the middle estimate sits 2.4-fold (0.38 log units) below what was measured; the range from low to high includes it.
By their numbers in this assay, from the lowest: compound 3; then compound 4; then compounds 1 and 2 (each within the scatter of the next).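

Notes on the sulfur substituent: in this assay, a ring held on the sulfur with aromatic carbon as the sulfur's neighbour still gives large steps from the small alkyl groups (a 14-fold lower number from compound 2 to compound 4 (1.15 log units; beyond the scatter) and a 13-fold lower number from compound 1 to compound 4 (1.12 log units; beyond the scatter)), so a large step at this position does not depend on a saturated carbon linking the sulfur to the ring. The aromatic ring alone does not set the level, however, since 2-acetyl-4-chlorophenyl in place of 2-nitrobenzyl, with equal heavy-atom counts on the two groups, gives a modest step (a 3.2-fold higher number from compound 3 to compound 4 (0.50 log units; beyond the scatter)) that lies beyond the scatter and leaves compound 3 with the lowest number of the series. No supporting data bear on what lies behind this difference.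

This single change removes the saturated carbon and exchanges the ring substituents together, so the compounds shown do not divide the step among the linkage, the nitro group, the acetyl group and the chlorine. Also open, going by these compounds, is how the number responds to a plain benzyl or phenyl group on the sulfur, to an amine or a carboxylic acid on the ring, or to a longer chain carrying the ring.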